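The source may report more compounds than this note shows. Statements on the series, on what has been measured and on what is new or still open speak of the compounds shown alone.

Compound 1 `CCn1c(SCC(=O)Nc2ccc(C(C)=O)cc2)nnc1-c1ccc(OC)c(OC)c1` and compound 2 `CCn1c(SCC(=O)Nc2ccc(C(C)=O)cc2)nnc1-c1cc(OC)c(OC)c(OC)c1` share one core, while compound 3 `C=CCn1c(SCC(=O)Nc2ccc(/C(C)=N/O)cc2)nnc1-c1ccc(OC)c(OC)c1` and compound 4 `C=CCn1c(SCC(=O)Nc2ccc(/C(C)=N/O)cc2)nnc1-c1cc(OC)c(OC)c(OC)c1` share another; the difference between the two cores is not broken down here. In a functional assay on the whole organism (strain albino) for inhibition, with Rattus norvegicus as the target, read by paw edema, with stated times of 30 min and 5 h, at a dose of 0.28 mmol/kg by the oral route (on this read-out higher numbers stand for more inhibition at the one dose given (going by the name of the read-out) and lower numbers for less inhibition), compound 1 gives 66%. In this assay compound 2 gives 64%. The change between these two is methoxy in place of hydrogen on an aromatic carbon and it made a step of a number 2 percentage points lower from compound 1 to compound 2 (within the scatter). In this assay compound 3 gives 79%, a number that stands higher than those of compound 1 and compound 2 by more than the usual scatter. The same change is now made on the other core: methoxy in place of hydrogen on an aromatic carbon carries compound 3 into compound 4. The place is described in the same words both times, so it is the same change, and it occurs twice among these four compounds. Going by the values given here, the one earlier step of this change stayed within the scatter. On that basis the expected step is a number 2 percentage points lower from compound 3 to compound 4 (within the scatter). Compound 4 is therefore estimated at 77% in this assay, with 65% and 88% as the ends of the expected range.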

Compound 4, a percentage reported as inhibition, in the whole organism at one dose (the size of the read-out at that dose, not a potency): 64%
Compound 4: middle estimate off by 13 percentage points, on the high side; the whole stated range lies above it.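

On the core of compound 3, methoxy in place of hydrogen on an aromatic carbon gave a number 15 percentage points lower from compound 3 to compound 4 (beyond the scatter) in this assay, so on this core the added methoxy goes with a real fall in the read-out. On the core of compound 1, the same change gave a number 2 percentage points lower from compound 1 to compound 2 (within the scatter), yet the two steps cannot be told apart, as their gap is no larger than two such steps can scatter: the same change on two cores in this assay, a number 2 percentage points lower (within the scatter) from compound 1 to compound 2 and a number 15 percentage points lower (beyond the scatter) from compound 3 to compound 4, 13 percentage points apart, within the scatter of two such steps. This gives no firm sign that the core alters what this methoxy does, but it does not show that the step carries over unchanged either, since one pair on each core is too little to settle the matter.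

The compounds shown leave open how another group at this place, such as ethoxy, a hydroxyl or an amine, would behave. They also leave open whether the step would hold on a further core, and which of the differences between the two cores, if any, bears on its size.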